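Swapping isopropylcarbamoyl for 3-hydroxypropyl in the series

This account rests on a few compounds, and the source may have more. Where it says the series, first, only, none or still open, it means among the compounds named here.

In an ADME assay on CEM-SS cells (Homo sapiens) for cytotoxicity, read by XTT assay (a higher number here means that more compound is tolerated, a lower number that less compound is tolerated), compound 1 (`CN(O)C(=O)c1cc2ccn(Cc3ccc(F)cc3)c2cn1`) gives 135000 nM. Compound 2 (`CC(C)NC(=O)c1cn(Cc2ccc(F)cc2)c2cnc(C(=O)N(C)O)cc12`) gives > 100000 nM, which is a limit and not a number. Compound 3 (`CN(O)C(=O)c1cc2c(CCCO)cn(Cc3ccc(F)cc3)c2cn1`) carries 3-hydroxypropyl in place of isopropylcarbamoyl on an aromatic carbon. Within the data shown here, the only measured step that bears on this change is a step that the limit leaves unreadable from compound 1 to compound 2, so no size carries over, and no step beyond the scatter is expected in this assay. The expectation therefore rests on compound 1 at 135000 nM. The estimate implies a number no higher from compound 2 to compound 3 (the limit leaves the size open) as the expected step. Compound 3 is expected at 100000 nM, with an estimated range of 35000 nM to 250000 nM.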

Compound 3, half-maximal cytotoxic concentration: > 10000 nM
Compound 3: only a limit was reported; the forecaster's own chance of this, stated with the estimate: 45%; the middle value does not contradict the limit.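

In this assay compound 3 gives > 10000 nM, which is a limit and not a number. The steps from compound 1 and from compound 2 to compound 3 cannot be read. From the compounds shown here alone, how 3-hydroxypropyl compares with isopropylcarbamoyl or hydrogen in this assay stays open.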